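Swapping the Pyridyl Arm for a Fluorophenyl Arm

The source may hold more compounds than are shown below. What is called first, only, known or untested is meant among the compounds shown, and "the series" means these compounds.

Compound 1 `O[C@@H](c1ccccc1)[C@H]1CO[C@H](c2ccccc2)[C@@H](C/C=C/c2ccccc2)C1` carries a phenyl on a double-bonded chain carbon bound to a double-bonded chain carbon, and in a functional assay on HL-60 cells (Homo sapiens) for cytotoxicity, read by WST assay, with a stated time of 48 h (a lower number here means a stronger inhibitor, a higher number a weaker inhibitor), compound 1 gives 7040 nM. Compound 2 `CCCCCC/C=C/C[C@H]1C[C@@H]([C@@H](O)c2ccccc2)CO[C@@H]1c1ccccc1` gives 4990 nM in this assay, and a 1.4-fold lower number from compound 1 to compound 2 (0.15 log units; within the scatter). Compound 3 `O[C@@H](c1ccccc1)[C@H]1CO[C@H](c2ccccc2)[C@@H](C/C=C/c2ccccn2)C1` gives 36400 nM in this assay, the highest number of the three. The two steps that reach it, a 5.2-fold higher number from compound 1 to compound 3 (0.71 log units; beyond the scatter) and a 7.3-fold higher number from compound 2 to compound 3 (0.86 log units; beyond the scatter), are both modest yet beyond the scatter.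

Compound 4 `O[C@@H](c1ccccc1)[C@H]1CO[C@H](c2ccccc2)[C@@H](C/C=C/c2ccc(F)cc2)C1` differs from compound 3 in one place: 4-fluorophenyl in place of pyridin-2-yl on a double-bonded chain carbon bound to a double-bonded chain carbon. Both steps above bear on this change, since each replaced a carbon-only group with the pyridin-2-yl and raised the number. Moving back to a carbon-only ring should therefore lower the number by a similar modest amount. Because compound 1 gives 7040 nM with phenyl at the same place, compound 4 is expected to land near that value, with an estimated step of a 4.6-fold lower number from compound 3 to compound 4 (0.66 log units; beyond the scatter). Compound 4 is thus estimated at 8000 nM in this assay, within 3500 nM to 18000 nM.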

Compound 4, half-maximal inhibitory concentration: 8110 nM
Compound 4: the middle estimate sits 1.0-fold (0.01 log units) below what was measured; the range from low to high includes it.
By their numbers in this assay, from the lowest: compounds 2, 1 and 4 (each within the scatter of the next); then compound 3.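

In this assay the move from pyridin-2-yl to 4-fluorophenyl gives a 4.5-fold lower number from compound 3 to compound 4 (0.65 log units; beyond the scatter) as a modest step, showing that a second carbon-only aromatic ring at this place also parts from compound 3. Compound 4 stays within the scatter of both other carbon-only arms, with a 1.2-fold higher number from compound 1 to compound 4 (0.06 log units; within the scatter) for fluoro in place of hydrogen on an aromatic carbon and a 1.6-fold higher number from compound 2 to compound 4 (0.21 log units; within the scatter) for 4-fluorophenyl in place of hexyl, so among these four compounds only the pyridin-2-yl arm of compound 3 stands apart. Nothing given here explains this difference.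

On these data alone, whether pyridin-3-yl or pyridin-4-yl would track pyridin-2-yl or the carbon-only arms stays open. So does what an amine or a carboxylic acid would do at this place.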